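This account rests on a few compounds, and the source may have more. Where it says the series, first, only, none or still open, it means among the compounds named here.

Compound 1 `Cn1c(=O)c(=O)n(C2CCCC2)c2nc(N/N=C/c3ccco3)ncc21` gives 72200 nM in a functional assay on PC-3 cells (Homo sapiens) for antiproliferative activity, read by MTT assay; on this read-out lower numbers stand for stronger inhibition and higher numbers for weaker inhibition.
Compound 2 `Cc1cc(C)c(/C=N/Nc2ncc3c(n2)n(C2CCCC2)c(=O)c(=O)n3C)c(C)c1` gives 13900 nM in this assay.
Compound 3 `COc1ccc(/C=N/Nc2ncc3c(n2)n(C2CCCC2)c(=O)c(=O)n3C)c(OC)c1` gives only a limit of this assay, > 100000 nM.

Among the measured compounds shown here, compound 3 thus stands at a limit rather than at a number; it is the one value among the three that sits there (the limit of > 100000 nM in this assay, at which 1 of the 3 values shown sits). Compound 4 `Cn1c(=O)c(=O)n(C2CCCC2)c2nc(N/N=C/c3ccccc3F)ncc21` differs from it by 2-fluorophenyl in place of 2,4-dimethoxyphenyl on a carbon with a double bond to nitrogen. Two measured steps lead into compound 3 and bear on this change: an at least 1.3-fold higher number from compound 1 to compound 3 (0.14 log units; that floor lies within the scatter) and an at least 7.1-fold higher number from compound 2 to compound 3 (0.85 log units; beyond the scatter). Both arrive at the limit, so a move away from the 2,4-dimethoxyphenyl group has so far given numbers that were equal or lower. A modest drop is therefore expected, an at least 2.0-fold lower number from compound 3 to compound 4 (0.30 log units; that floor lies within the scatter). Compound 4 is estimated at 50000 nM, with a range from 15000 nM to 150000 nM.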

Compound 4, half-maximal inhibitory concentration: 27600 nM
Estimate against measurement, compound 4: 1.8-fold (0.26 log units) above; the measured number falls inside the stated range.
By their numbers in this assay, from the lowest: compounds 2 and 4 (each within the scatter of the next); then compound 1. At a limit, above all of these: compound 3.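

Compound 3 remains at a limit of the assay rather than a number: the limit of > 100000 nM in this assay, at which 1 of the 4 values shown sits.

With 2-fluorophenyl on this carbon, the results are an at least 3.6-fold lower number from compound 3 to compound 4 (0.55 log units; beyond the scatter) and a 2.6-fold lower number from compound 1 to compound 4 (0.42 log units; beyond the scatter), so a single fluorine on the phenyl ring is enough to clear that limit and to pass furan-2-yl. Set against 2,4,6-trimethylphenyl, it shows a 2.0-fold higher number from compound 2 to compound 4 (0.30 log units; within the scatter), so these two differently substituted phenyl groups read alike and 2,4-dimethoxyphenyl stands as the exception among the phenyl groups.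

On these data alone, it remains open whether one methoxy group alone would reach the limit. Also open, as far as these compounds go, is how a phenyl ring carrying an amine or a carboxylic acid would read.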